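The compounds below may be only part of what the source reports. "The series", "measured", "known", "first", "only" and "open" are said of these compounds alone.

In a functional assay on B16 cells (Mus musculus) for cytotoxicity, read by CCK-8 assay, with a stated time of 24 h (on this read-out higher numbers stand for weaker inhibition and lower numbers for stronger inhibition), compound 1 (`COc1ccccc1Oc1c(N)nc(-c2ccccc2)nc1Cl`) gives 4610 nM, compound 2 (`COc1ccccc1Oc1c(N)nc(-c2ccc(C)cc2)nc1Cl`) gives 17400 nM and compound 3 (`COc1cccc(-c2nc(N)c(Oc3ccccc3OC)c(Cl)n2)c1`) gives 23600 nM. Compound 3 therefore sits level with compound 2 and well above compound 1. Compound 4 (`COc1ccc(-c2nc(N)c(Oc3ccccc3OC)c(Cl)n2)cc1`) has the same atoms as compound 3, joined differently: 4-methoxyphenyl in place of 3-methoxyphenyl on an aromatic carbon. The swap takes place on the aromatic carbon between two ring nitrogen atoms.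

Within the data shown here, no measured pair moves a methoxy group in this way, so the evidence is indirect. Putting methyl on the phenyl ring gave a 3.8-fold higher number from compound 1 to compound 2 (0.58 log units; beyond the scatter), and putting methoxy on it gave a 5.1-fold higher number from compound 1 to compound 3 (0.71 log units; beyond the scatter). Both were modest rises. Replacing 4-methylphenyl with 3-methoxyphenyl gave a 1.4-fold higher number from compound 2 to compound 3 (0.13 log units; within the scatter), so a group's identity and position together changed little once the ring carried a substituent.

In this assay the expected step is therefore small, a 1.2-fold lower number from compound 3 to compound 4 (0.09 log units; within the scatter), with no shift beyond the scatter anticipated. For compound 4 the estimated value is 19000 nM, with an expected range from 8000 nM to 45000 nM.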

Compound 4, half-maximal inhibitory concentration: 47800 nM
Beside the measured number, compound 4's estimate is 2.5-fold (0.40 log units) below it, outside the stated range (above it).
By their numbers in this assay, from the lowest: compound 1; then compounds 2 and 3 (each within the scatter of the next); then compound 4.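

Moving the methoxy group gives a 2.0-fold higher number from compound 3 to compound 4 (0.31 log units; beyond the scatter) in this assay, so the spot it occupies on the phenyl ring matters, which no earlier pair could test. The group's identity matters too: 4-methoxyphenyl in place of 4-methylphenyl gives a 2.7-fold higher number from compound 2 to compound 4 (0.44 log units; beyond the scatter) and, against the unsubstituted phenyl, methoxy gives a 10-fold higher number from compound 1 to compound 4 (1.02 log units; beyond the scatter), leaving compound 4 the weakest of the four and compound 1, which has no substituent on that ring, the strongest. Nothing available here explains why the two methoxy placements differ.

The compounds shown leave open whether any group on this phenyl ring can match compound 1 or go lower, for example a fluoro, a hydroxyl or an amine. As far as these compounds go, it also remains open whether these differences hold in other cell types.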